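Methyl to chloro on the shared core: compound 3

This account rests on a few compounds, and the source may have more. Where it says the series, first, only, none or still open, it means among the compounds named here.

Measured so far in a functional assay on the whole organism (strain Sprague-Dawley) for inhibition, with Rattus norvegicus as the target; a higher number here means that more compound is needed for the effect, a lower number that less compound is needed:
- compound 1, `COc1cccc2c(=O)c(-c3nn[nH]n3)c[nH]c12`, gives 0.15 mg/kg
- compound 2, `Cc1cccc2c(=O)c(-c3nn[nH]n3)c[nH]c12`, gives > 5 mg/kg

The value of compound 2 is a limit of the assay, not a number; compound 2 sits at the limit of > 5 mg/kg in this assay, at which 1 of the 2 values shown sits. Going by the values given here, compound 1 stands well inside the measurable range, and the one step connecting the two, an at least 33-fold higher number from compound 1 to compound 2 (1.52 log units; beyond the scatter), is the only measured step.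

The next compound, compound 3, `O=c1c(-c2nn[nH]n2)c[nH]c2c(Cl)cccc12`, is reached from compound 2 by chloro in place of methyl on an aromatic carbon. Among the compounds with values here, no measured step in this assay touches a chloro group, so nothing here speaks directly to this replacement. Within the data shown here, the one step on record, an at least 33-fold higher number from compound 1 to compound 2 (1.52 log units; beyond the scatter), only shows that exchanging the group at this place can move the read-out far beyond the scatter. With compound 2 known only as a limit, the starting point itself is open.

Compound 3 is therefore expected near 3 mg/kg, within 0.5 mg/kg to 20 mg/kg, which would mean an expected step of an at least 1.6-fold lower number from compound 2 to compound 3 (0.22 log units; that floor lies within the scatter), with a fair chance that the assay again reports only a limit.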

Compound 3, minimum effective dose: 0.078 mg/kg
Estimate against measurement, compound 3: 38-fold (1.59 log units) above; the measured number lies below the stated range.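

Chloro in place of methoxy gives a 1.9-fold lower number from compound 1 to compound 3 (0.28 log units; within the scatter), so in this assay these two groups cannot be told apart at this place on the shared core. Chloro in place of methyl gives an at least 64-fold lower number from compound 2 to compound 3 (1.80 log units; beyond the scatter), which shows that the large step seen earlier belongs to methyl specifically and that a group without oxygen can still read well inside the measurable range, since neither chloro nor methyl carries hydrogen-bond donors or acceptors, and only methyl stands apart among the three groups shown. The size of that step remains a floor, as compound 2 is a limit of the assay and not a number: the limit of > 5 mg/kg in this assay, at which 1 of the 3 values shown sits.

The three compounds do not show what separates methyl from chloro and methoxy, as a single exchange of one heavy atom for another moves the read-out this far and nothing shown accounts for it. Going by these compounds, how fluoro, bromo, a longer chain such as ethoxy, or an amine would read at this place in this assay stays open, as does whether chloro elsewhere on the six-membered aromatic ring would behave alike.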